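Swapping the para substituent: from trifluoromethyl to carbamoyl

This account rests on a few compounds, and the source may have more. Where it says the series, first, only, none or still open, it means among the compounds named here.

Measured so far:
- compound 1 `Cc1ccc(C(=O)Nc2cc(-c3ccccc3)nn2-c2ccccc2)cc1`: 780 nM
- compound 2 `O=C(Nc1cc(-c2ccccc2)nn1-c1ccccc1)c1ccc(OC(F)(F)F)cc1`: 265 nM
- compound 3 `O=C(Nc1cc(-c2ccccc2)nn1-c1ccccc1)c1ccc(C(F)(F)F)cc1`: 990 nM

In an assay on HEK293 cells for displacement of a labelled ligand from metabotropic glutamate receptor 5 (Rattus norvegicus) (a higher number here means a weaker inhibitor, a lower number a stronger inhibitor), compound 3 gives the highest of the three numbers; its gap to compound 1 is within the scatter a 1.3-fold higher number from compound 1 to compound 3 (0.10 log units; within the scatter), while compound 2 stands apart a 3.7-fold higher number from compound 2 to compound 3 (0.57 log units; beyond the scatter). Compound 4 `NC(=O)c1ccc(C(=O)Nc2cc(-c3ccccc3)nn2-c2ccccc2)cc1` differs from compound 3 by one change: carbamoyl in place of trifluoromethyl on an aromatic carbon. Among the compounds with values here, none of the measured steps involves carbamoyl; the closest comparisons, a 2.9-fold lower number from compound 1 to compound 2 (0.47 log units; beyond the scatter) and a 1.3-fold higher number from compound 1 to compound 3 (0.10 log units; within the scatter), show that changing this group has moved the number modestly at most. For compound 4, the expected step of a 1.1-fold lower number from compound 3 to compound 4 (0.04 log units; within the scatter) is therefore small, in no confident direction. Compound 4 is estimated at 900 nM, with a range from 200 nM to 4000 nM.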

Compound 4, inhibition constant: > 10000 nM
Compound 4: a limit, no number; the forecaster's own chance of this, stated with the estimate: 10%; at least 11-fold (1.04 log units) between middle value and limit.
By their numbers in this assay, from the lowest: compound 2; then compounds 1 and 3 (each within the scatter of the next). At a limit, above all of these: compound 4.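

Compound 4 gives a limit of the assay, not a number: the limit of > 10000 nM in this assay, at which 1 of the 4 values shown sits.

Among methyl, trifluoromethyl and trifluoromethoxy, swaps at this position moved the number modestly at most, yet carbamoyl brings an at least 10-fold higher number from compound 3 to compound 4 (1.00 log units; beyond the scatter), an at least 12-fold higher number from compound 1 to compound 4 (1.10 log units; beyond the scatter) and an at least 37-fold higher number from compound 2 to compound 4 (1.57 log units; beyond the scatter). So this position is not indifferent to the group it carries, and the change to carbamoyl, with its hydrogen-bond donor and acceptor where trifluoromethyl has neither, is the first large step seen here.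

From the compounds shown here alone, how a nitrile, a methyl ester or an amine would fare at this position stays open, and the actual number for compound 4 remains unknown.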